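A few compounds are considered here, and "the series" means these few. Any claim that something is new, unique, unknown or untested is made for them only; others in the source may bear on it.

Going by the values given here, compound 3 `COc1ccccc1-c1cc(CN(C)C)ccc1Cl` is the reference point here: in an assay on isolated protein for binding affinity to 5-hydroxytryptamine receptor 6 (Homo sapiens) (a higher number here means a weaker inhibitor, a lower number a stronger inhibitor), compound 3 gives 440 nM, the only actual number among the values so far. Compound 1 `CCCN(CCC)Cc1ccc(Cl)c(-c2ccccc2OC)c1` reaches only a limit of the assay, > 10000 nM. Compound 2 `COc1ccccc1-c1cc(C2CCN(C)C2)ccc1Cl` likewise stops at a limit, > 10000 nM. Both rest on the same boundary, (the limit of > 10000 nM in this assay, at which 2 of the 3 values shown sit). Among the compounds with values here, the steps of an at least 22-fold lower number from compound 1 to compound 3 (1.35 log units; beyond the scatter) and an at least 22-fold lower number from compound 2 to compound 3 (1.35 log units; beyond the scatter) are thus both large, and both arrive at the sole measured number. Compound 4 `CCN(CC)Cc1ccc(Cl)c(-c2ccccc2OC)c1` has not been measured; it differs from compound 3 by diethylamino in place of dimethylamino on a saturated chain carbon bound to an aromatic carbon. Diethylamino is longer than dimethylamino and shorter than dipropylamino, so the step that bears on it is an at least 22-fold lower number from compound 1 to compound 3 (1.35 log units; beyond the scatter), in which the dipropylamino compound gave only a limit. Going back toward a longer chain is expected to move the number upward, by less than that whole step though still beyond the scatter. The expected step for compound 4 is estimated as a 4.5-fold higher number from compound 3 to compound 4 (0.66 log units; beyond the scatter). Compound 4 is estimated at 2000 nM, with a range from 700 nM to 8000 nM in this assay.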

Compound 4, inhibition constant: 2000 nM
For compound 4 middle estimate and measured number coincide at the digits printed, within the range that was stated.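

In this assay, the change to diethylamino gives a 4.5-fold higher number from compound 3 to compound 4 (0.66 log units; beyond the scatter), so adding carbon to the amine on this saturated chain carbon already weakens binding at this smaller size, a step the earlier limit could not size. Compound 4 nevertheless keeps a real number, and the steps of an at least 5.0-fold lower number from compound 1 to compound 4 (0.69 log units; beyond the scatter) and an at least 5.0-fold lower number from compound 2 to compound 4 (0.69 log units; beyond the scatter) place it ahead of both other compounds, giving the order dimethylamino, diethylamino, dipropylamino among these three amines. Those two steps give only minimum sizes, as each starts from a limit rather than a number: the limit of > 10000 nM in this assay, at which 2 of the 4 values shown sit.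

On these data alone, it remains open whether a smaller methylamino group or a plain primary amine would lower the number further. As far as these compounds go, it is equally open whether a ring amine such as pyrrolidin-1-yl, placed on the same carbon, would fit this order.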